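A Halogen Swap on the Amide Ring

This account rests on a few compounds, and the source may have more. Where it says the series, first, only, none or still open, it means among the compounds named here.

Compound 1, `Cc1ccc(N2C(=O)C/C(=C\c3cccc(C(=O)Nc4cccc(F)c4)c3)C2=O)cc1`, was tested in an ADME assay on SW480 cells (Homo sapiens) for cytotoxicity, read by MTT assay, with a stated time of 72 h; a lower number here means a stronger inhibitor, a higher number a weaker inhibitor. In this assay, among the compounds with values here, compound 1 gives 96900 nM, and this is the only plain number among the values shown. Compound 2, `COc1ccc(NC(=O)c2cccc(/C=C3\CC(=O)N(c4ccccc4)C3=O)c2)c(C)c1`, was tested in the same way. In this assay compound 2 gives > 100000 nM, which is a limit of the assay and not a number. Within the data shown here, compound 1 therefore stands as the single definite reading, while the other reading sits at the limit of > 100000 nM in this assay, at which 1 of the 2 values shown sits. Both readings point to weak cytotoxicity.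

Compound 3, `Cc1ccc(N2C(=O)C/C(=C\c3cccc(C(=O)Nc4ccc(Cl)cc4)c3)C2=O)cc1`, differs from compound 1 by 4-chlorophenyl in place of 3-fluorophenyl on an amide-type nitrogen. Among the measured compounds shown here, no measured pair of compounds shows this same change, so nothing here gives its size directly. Since the two readings that are available both lie at the weak end, the change is expected to bring no step beyond the scatter, and the expected step is a 1.0-fold lower number from compound 1 to compound 3 (0.01 log units; within the scatter). For compound 3 the estimated value in this assay is 95000 nM, with a likely range from 40000 nM to 200000 nM, and a fair chance that only a limit is reported.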

Compound 3, half-maximal inhibitory concentration: > 100000 nM
Compound 3: only a limit was reported (the forecaster's own chance of this, stated with the estimate: 45%); at least 1.0-fold (0.02 log units) between middle value and limit.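

At this position, the aromatic group on the amide-type nitrogen, putting 4-chlorophenyl in place of 3-fluorophenyl gives an at least 1.0-fold higher number from compound 1 to compound 3 (0.01 log units; that floor lies within the scatter). Compound 3 gives > 100000 nM, which is a limit of the assay and not a number, so the true size of the step cannot be read, but this swap brings no gain in strength that this assay can show. Within the data shown here, this is the first direct look at a change in this place, and it leaves the series at the weak end of the scale: the limit of > 100000 nM in this assay, at which 2 of the 3 values shown sit.

The swap changes both the halogen and where it sits on the ring, and the compounds shown do not separate these two changes. Also open, on these data alone, is whether a group of a different kind on this ring, such as an amine or a carboxylic acid, would bring the number down into a range where steps can be measured as plain values.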